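Replacing the Dimethoxyphenyl Thioether in Compound 1

The source may report more compounds than this note shows. Statements on the series, on what has been measured and on what is new or still open speak of the compounds shown alone.

Measured compounds:
compound 1: `COc1ccc(SCc2ccc(/C=C/C(=O)Nc3ccccc3N)cc2)cc1OC`, 80.6%
compound 2: `Nc1ccccc1NC(=O)c1ccc(CSc2nccc(C(F)(F)F)n2)cc1`, 95.1%
compound 3: `COc1ccc(SCc2ccc(C(=O)Nc3ccccc3N)cc2)cc1`, 70.7%

All three were tested in a functional assay on A549 cells (Homo sapiens) for inhibition, read by CCK-8 assay, with a stated time of 72 h, tested at 8 uM; a higher number here means more inhibition of growth at the concentration tested, a lower number less inhibition of growth. Among the three numbers, compound 1 stands second highest. Its nearest neighbour is compound 3, whose value lies within the scatter of compound 1, so the two cannot be told apart on these numbers. The furthest is compound 2, which lies higher than compound 1 by more than the scatter, so compound 2 shows clearly more growth inhibition than compound 1 in this assay.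

Compound 4, `Nc1ccccc1NC(=O)/C=C/c1ccc(CSc2cccc(F)c2)cc1`, has not yet been measured. It differs from compound 1 in one place: 3-fluorophenyl in place of 3,4-dimethoxyphenyl on a sulfur. Going by the values given here, no measured pair of compounds shows this same change, so the data give no direct size for the step. The change keeps the rest of compound 1 untouched, and the three measured values all fall in a fairly narrow band, so the expectation is a step that stays within the scatter, with no clear direction.

On this basis, compound 4 is expected to give 78% in this assay, in a range from 62% to 92%. The step of a number 2.6 percentage points lower from compound 1 to compound 4 (within the scatter) that this estimate implies is expected to be small.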

Compound 4, percent growth inhibition at one concentration: 56.6%
For compound 4 the middle estimate is 21.4 percentage points above the measured one; the whole stated range lies above it.
By their numbers in this assay, from the lowest: compound 4; then compounds 3 and 1 (each within the scatter of the next); then compound 2.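

In this assay, exchanging 3,4-dimethoxyphenyl for 3-fluorophenyl on the sulfur gives a number 24 percentage points lower from compound 1 to compound 4 (beyond the scatter). Going by these compounds alone, this is the first comparison here in which only one place changes, and it shows that the group on the sulfur is not a neutral part of compound 1, since this change alone is enough to lower growth inhibition by more than the usual scatter. The exchange alters several things at once, going from 10 heavy atoms to 7 and from 2 hydrogen-bond acceptors to 0 while also bringing in fluorine, and no measurement bears on which of these matters.

The compounds shown leave open whether the lower number comes from losing the two methoxy groups or from adding the fluorine. A plain phenyl group or an aminophenyl group on the same sulfur, with the rest of compound 1 unchanged, would help to separate these two possibilities.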